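Chain lengthening on the alkene substituent of the side chain

The source may report more compounds than this note shows. Statements on the series, on what has been measured and on what is new or still open speak of the compounds shown alone.

Compound 2 `C=C1/C(=C\C=C(/CCCCCC)c2cccc(CCCCCC(C)(C)O)c2)C[C@@H](O)C[C@@H]1O` gives 10 nM in an assay on MCF7 cells for agonist activity at vitamin D3 receptor (Homo sapiens), read by a luciferase reporter, with a stated time of 24 h; a higher number here means that more compound is needed for the effect, a lower number that less compound is needed. Going by the values given here, of the two numbers so far it is the higher, but its nearest neighbour, compound 1 `C=C1/C(=C\C=C(/CCC)c2cccc(CCCCCC(C)(C)O)c2)C[C@@H](O)C[C@@H]1O` with 8.6 nM, sits within the scatter of it, so no order between the two can be read. Compound 3 `C=C1/C(=C\C=C(/CCCCCCC)c2cccc(CCCCCC(C)(C)O)c2)C[C@@H](O)C[C@@H]1O` is not yet measured; it differs from compound 2 by methyl in place of hydrogen on a saturated chain carbon, six bonds along the chain from a double-bonded chain carbon. Among the compounds with values here, the only step so far that bears on this change is a 1.2-fold higher number from compound 1 to compound 2 (0.07 log units; within the scatter), a lengthening of the same chain that left this assay essentially unchanged. With a single such step and a far smaller change now, the expectation is no shift beyond the scatter. Compound 3 is therefore expected to give 11 nM in this assay, with the range from 4 nM to 30 nM, which means an expected step of a 1.1-fold higher number from compound 2 to compound 3 (0.04 log units; within the scatter).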

Compound 3, half-maximal effective concentration: 29 nM
Compound 3: middle estimate off by 2.6-fold (0.42 log units), on the low side; the range from low to high includes it.
By their numbers in this assay, from the lowest: compounds 1 and 2 (each within the scatter of the next); then compound 3.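

In this assay this position is not indifferent to chain length: methyl in place of hydrogen, six bonds along the chain from a double-bonded chain carbon, gives a 2.9-fold higher number from compound 2 to compound 3 (0.46 log units; beyond the scatter) as a modest step beyond the scatter, although the larger propyl addition gave only a 1.2-fold higher number from compound 1 to compound 2 (0.07 log units; within the scatter) and stayed within it. Taken from the shortest chain shown, the change amounts to a 3.4-fold higher number from compound 1 to compound 3 (0.53 log units; beyond the scatter) and is also modest, so among these three compounds the only shift beyond the scatter appears with the final methyl. No measurement available here explains this shift.

Three chain lengths cannot show whether the number keeps rising with a still longer chain or levels off. Also open, going by these compounds, is how this position responds to a branched chain, such as isopropyl, or to a chain ending in an amine or a carboxylic acid.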